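Methyl removal next to ring nitrogen in compound 2

The source may report more compounds than this note shows. Statements on the series, on what has been measured and on what is new or still open speak of the compounds shown alone.

Going by the values given here, in a functional assay on CHO cells for antagonist activity at metabotropic glutamate receptor 5 (Rattus norvegicus), read by FLIPR and calcium flux (a higher number here means a weaker inhibitor, a lower number a stronger inhibitor), compound 2 `Cc1ccc2cnc(-c3cc(Cl)cc(Cl)c3)nc2n1` gives 0.72 nM, the only number in the set. Compound 1 `Cc1ccc2cnc(-c3ccc(C#N)cc3)nc2n1` gives > 30000 nM in this assay, which is a limit of the assay rather than a number (the limit of > 30000 nM in this assay, at which 1 of the 2 values shown sits). Compound 3 `Clc1cc(Cl)cc(-c2ncc3cccnc3n2)c1` differs from compound 2 by hydrogen in place of methyl on an aromatic carbon, next to the ring nitrogen. Among the compounds with values here, no measured pair shows this change; the step of a 6.9-fold higher number from compound 2 to compound 3 (0.84 log units; beyond the scatter) is expected to be a modest loss, probably beyond the scatter. Compound 3 is estimated at 5 nM in this assay, between 1 nM and 30 nM.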

Compound 3, half-maximal inhibitory concentration: 228 nM
For compound 3 the middle estimate is 46-fold (1.66 log units) below the measured one; measured number outside the range, above it.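

In this assay, the methyl on this aromatic carbon, next to the ring nitrogen, matters far more than one heavy atom might suggest: hydrogen in its place gives a 320-fold higher number from compound 2 to compound 3 (2.50 log units; beyond the scatter) in the series. The position is therefore sensitive to this small change. Without the methyl, compound 3 still gives a measured value of 228 nM.

Going by these compounds, whether an ethyl, a methoxy, a chlorine or an amine at this position would hold the potency of compound 2 stays open. Nothing shown bears on why this step is so large.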